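The source may report more compounds than this note shows. Statements on the series, on what has been measured and on what is new or still open speak of the compounds shown alone.

Compound 1, `O=C(Nn1c(-c2cccc([N+](=O)[O-])c2)nc2c(-c3ccco3)n[nH]c2c1=O)c1cccnc1`, carries a nitro group on its phenyl ring. In a functional assay on A549 cells (Homo sapiens) for cytotoxicity, read by sulforhodamine B assay, with a stated time of 2 days, tested at 100 uM (a lower number here means less inhibition, a higher number more inhibition at the concentration tested (going by the name of the read-out)), compound 1 gives 1.51%. Compound 2, `COc1cccc(-c2nc3c(-c4ccco4)n[nH]c3c(=O)n2NC(=O)c2cccnc2)c1`, differs from it by one change, (methoxy in place of nitro on an aromatic carbon), and in this assay compound 2 gives 14.9%. That single change made a step of a number 13.4 percentage points higher from compound 1 to compound 2 (beyond the scatter).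

Compound 3, `CCCc1n[nH]c2c(=O)n(NC(=O)c3ccccc3)c(-c3cccc([N+](=O)[O-])c3)nc12`, shares the nitrophenyl group with compound 1 but has a different core; the difference between the two cores is not broken down here. In this assay compound 3 gives 33.2%, which stands beyond the scatter from both compound 1 and compound 2.

Compound 4, `CCCc1n[nH]c2c(=O)n(NC(=O)c3ccccc3)c(-c3cccc(OC)c3)nc12`, is not yet measured. Among the compounds with values here, it differs from compound 3 by methoxy in place of nitro on an aromatic carbon, which is the same change, at the same kind of place, as the one from compound 1 to compound 2. An upward step of about a number 10.8 percentage points higher from compound 3 to compound 4 (beyond the scatter) is expected, because the same change gave a number 13.4 percentage points higher from compound 1 to compound 2 (beyond the scatter) on the other core. Within the data shown here, compound 4 is therefore estimated to give 44%, with a likely range from 22% to 66%, with wide room left since only one earlier example of the change exists.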

Compound 4, a percentage reported as inhibition, at one concentration (the size of the read-out at that concentration, not a potency): 20.7%
The estimate for compound 4 lay 23.3 percentage points above the measured number; measured number outside the range, below it.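

In this assay, putting methoxy in place of nitro made a step of a number 12.5 percentage points lower from compound 3 to compound 4 (beyond the scatter), which runs in the opposite direction to the step seen on the core of compound 1. Set side by side, the two steps differ by more than repeat measurements would explain, so the result of this change on one core could not be carried over to the other core in this series: the same change on two cores in this assay, a number 13.4 percentage points higher (beyond the scatter) from compound 1 to compound 2 and a number 12.5 percentage points lower (beyond the scatter) from compound 3 to compound 4, 25.9 percentage points apart, beyond the scatter of two such steps This shows only that the change behaved differently in these two pairs; it does not show which part of the cores is responsible or why, and the two pairs differ from each other in more than one place.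

The compounds shown leave open how an amine or a carboxylic acid in place of nitro or methoxy would behave on either core. They also leave open whether the methoxy-for-nitro change would raise or lower the number on any third core.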